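A few compounds are considered here, and "the series" means these few. Any claim that something is new, unique, unknown or untested is made for them only; others in the source may bear on it.

In a physicochemical assay for solubility, at pH 2 (on this read-out higher numbers stand for higher solubility and lower numbers for lower solubility), compound 1 `COC(=O)[C@@H](N)CSNC(=O)[C@@H](CCC(F)(F)F)N(Cc1ccc(-c2ncon2)cc1F)S(=O)(=O)c1ccc(Cl)cc1` gives 3900 ug/mL. Compound 2 `O=C(NSc1ccccc1)[C@@H](CCC(F)(F)F)N(Cc1ccc(-c2ncon2)cc1F)S(=O)(=O)c1ccc(Cl)cc1` returns only a limit of the assay, < 1 ug/mL. Compound 3 `N#CCCSNC(=O)[C@@H](CCC(F)(F)F)N(Cc1ccc(-c2ncon2)cc1F)S(=O)(=O)c1ccc(Cl)cc1` likewise returns only a limit, < 1 ug/mL. Compound 3 therefore stands at the floor of the values shown, (the limit of < 1 ug/mL in this assay, at which 2 of the 3 values shown sit), so its true position below that floor is not known. Compound 4 `CCOC(=O)[C@@H](N)CSNC(=O)[C@@H](CCC(F)(F)F)N(Cc1ccc(-c2ncon2)cc1F)S(=O)(=O)c1ccc(Cl)cc1` alters compound 3 by amino(ethoxycarbonyl)methyl in place of cyanomethyl on a saturated chain carbon bound to a sulfur. The measured steps that bear on this are an at least 3900-fold lower number from compound 1 to compound 3 (3.59 log units; beyond the scatter) and an at least 3900-fold lower number from compound 1 to compound 2 (3.59 log units; beyond the scatter). Because the new change nearly reverses an at least 3900-fold lower number from compound 1 to compound 3 (3.59 log units; beyond the scatter), a large rise is expected for compound 4, namely an at least 3000-fold higher number from compound 3 to compound 4 (3.47 log units; beyond the scatter). Compound 4 is estimated at 3000 ug/mL, with a range from 1000 ug/mL to 7000 ug/mL.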

Compound 4, solubility: 4300 ug/mL
The estimate for compound 4 lay 1.4-fold (0.16 log units) below the measured number; the range from low to high includes it.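

In this assay, the 2-amino-2-(ethoxycarbonyl)ethyl group on the sulfur gives a high number again, with an at least 4300-fold higher number from compound 3 to compound 4 (3.63 log units; beyond the scatter) and an at least 4300-fold higher number from compound 2 to compound 4 (3.63 log units; beyond the scatter). Going by these compounds, both steps start from a limit of the assay, so their true size stays unknown: the limit of < 1 ug/mL in this assay, at which 2 of the 4 values shown sit. Going from the methyl to the ethyl ester leaves the read-out within the scatter, with a 1.1-fold higher number from compound 1 to compound 4 (0.04 log units; within the scatter).

On these data alone, it remains open which part of this side chain matters, the amino group or the ester. A carboxylic acid in place of the ester, or a chain carrying only the amine, would separate the two.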